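Series notes: substituent changes on the double-bonded nitrogen

The source may report more compounds than this note shows. Statements on the series, on what has been measured and on what is new or still open speak of the compounds shown alone.

Compound 1 `CCC/N=C(\NC#N)Nc1cccnc1` and compound 2 `CCC(CC)/N=C(\NC#N)Nc1cccnc1` share one core and differ only in the group on the double-bonded nitrogen. In a functional assay on the whole organism (blood, strain Wistar-Okamoto) with Rattus norvegicus as the target, with a stated time of 5 days (a lower number here means that less compound is needed, a higher number that more compound is needed for the effect), compound 1 gives 20 mg/kg and compound 2 gives 20 mg/kg. The step of no change at the digits printed from compound 1 to compound 2 (within the scatter) covers this pair. Compound 2 thus stands level with compound 1 at the digits shown, and no other measured compound is available for comparison.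

Compound 3 `N#CN/C(=N\C1CC1)Nc1cccnc1` has not yet been measured. It differs from compound 2 by cyclopropyl in place of pentan-3-yl on a double-bonded nitrogen. Going by the values given here, the group that leaves, pentan-3-yl, is the same one that entered in the only measured step that bears here, no change at the digits printed from compound 1 to compound 2 (within the scatter), which was within the scatter. On that basis the expected step is none beyond the scatter, no change at the digits printed from compound 2 to compound 3 (within the scatter). Compound 3 is therefore estimated at 20 mg/kg, with a range from 10 mg/kg to 40 mg/kg.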

Compound 3, minimum effective dose: 20 mg/kg
Beside the measured number, compound 3's estimate shows no gap at the digits printed; the range from low to high includes it.
By their numbers in this assay, from the lowest: compounds 1, 2 and 3 (each within the scatter of the next).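

In this assay, going by these compounds alone, a ring stands on the double-bonded nitrogen for the first time, and cyclopropyl in place of pentan-3-yl gives no change at the digits printed from compound 2 to compound 3 (within the scatter), while cyclopropyl in place of propyl gives no change at the digits printed from compound 1 to compound 3 (within the scatter). The position thus takes a three-membered non-aromatic ring of carbon only as well as the two open chains, with all three compounds level in minimum effective dose, so neither branching nor ring closure separates them here. Nothing at hand gives a reason for this flat reading.

Going by these compounds, whether the level reading survives a longer chain, a phenyl ring or a chain bearing an amine on this nitrogen remains open. All three groups shown are made of carbon only, so the effect of a group containing oxygen or nitrogen at this position is also unknown.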